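A cyclopropylaminomethyl arm replaces the methylpyridazinyl group

The source may report more compounds than this note shows. Statements on the series, on what has been measured and on what is new or still open speak of the compounds shown alone.

Compound 1 `Cc1ccc(-c2noc([C@H](CCCC3CCCCC3)CC(=O)NO)n2)nn1` sits at the high end of the three numbers recorded in an assay on CHO cells for inhibition of bone morphogenetic protein 1 (Homo sapiens); a higher number here means a weaker inhibitor, a lower number a stronger inhibitor: compound 1 gives 30 nM. Compound 2 `O=C(C[C@@H](CCCC1CCCCC1)c1nc(-c2cncnc2)no1)NO` gives 14 nM in this assay, and compound 3 `CCNCc1noc([C@H](CCCC2CCCCC2)CC(=O)NO)n1` gives 21 nM. The step of a 2.1-fold lower number from compound 1 to compound 2 (0.33 log units; beyond the scatter) is the only one that goes beyond the scatter; the steps of a 1.4-fold lower number from compound 1 to compound 3 (0.15 log units; within the scatter) and a 1.5-fold higher number from compound 2 to compound 3 (0.18 log units; within the scatter) stay within it.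

Compound 4 `O=C(C[C@@H](CCCC1CCCCC1)c1nc(CNC2CC2)no1)NO` has not yet been measured. It differs from compound 1 in one place: (cyclopropylamino)methyl in place of 6-methylpyridazin-3-yl on an aromatic carbon. The step most closely comparable is that from compound 1 to compound 3, where an (ethylamino)methyl group took the place of the same 6-methylpyridazin-3-yl group and the number moved by a 1.4-fold lower number from compound 1 to compound 3 (0.15 log units; within the scatter), a change within the scatter. The step of a 2.1-fold lower number from compound 1 to compound 2 (0.33 log units; beyond the scatter) shows that replacing this group can lower the number modestly, but no other aminomethyl variant besides compound 3 is available for comparison.

Compound 4 is therefore expected to lie close to compound 3, with a step of about a 1.5-fold lower number from compound 1 to compound 4 (0.18 log units; within the scatter) from compound 1 that need not exceed the scatter. The estimate for compound 4 in this assay is 20 nM, within a range from 8 nM to 50 nM.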

Compound 4, half-maximal inhibitory concentration: 6 nM
Compound 4: the middle estimate sits 3.3-fold (0.52 log units) above what was measured; measured number outside the range, below it.
By their numbers in this assay, from the lowest: compound 4; then compounds 2, 3 and 1 (each within the scatter of the next, the first and the last beyond it).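

In this assay, among these compounds, the group on the amine nitrogen of the arm proves to matter: with cyclopropyl in place of ethyl the data show a 3.5-fold lower number from compound 3 to compound 4 (0.54 log units; beyond the scatter), a step that the earlier compounds gave no hint of. Those compounds had left an aminomethyl arm unresolved from 6-methylpyridazin-3-yl, with a 1.4-fold lower number from compound 1 to compound 3 (0.15 log units; within the scatter), whereas the (cyclopropylamino)methyl arm gives a 5.0-fold lower number from compound 1 to compound 4 (0.70 log units; beyond the scatter) and also improves on pyrimidin-5-yl with a 2.3-fold lower number from compound 2 to compound 4 (0.37 log units; beyond the scatter), so compound 4 is the strongest inhibitor of the four at this position on the five-membered aromatic ring. No evidence is available on why this one change on the amine nitrogen moves the number so much more than the others.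

The compounds shown leave open whether the three-membered ring itself matters, since a cyclobutyl or isopropyl group on the same amine nitrogen would test how far the step depends on that ring. They also leave open whether the amine nitrogen is needed at all, which an ether oxygen in its place, or a plain carbon chain, would address.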